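A few compounds are considered here, and "the series" means these few. Any claim that something is new, unique, unknown or untested is made for them only; others in the source may bear on it.

Working notes on the series. Compound 1 `COc1ccc(C(C)N(Cc2ccc(C(C)(C)C)cc2)Cc2cc3cc(Br)ccc3[nH]c2=O)cc1Cl` and compound 2 `CC(c1ccc(OC(F)(F)F)c(Cl)c1)N(Cc1ccc(C(C)(C)C)cc1)Cc1cc2cc(Br)ccc2[nH]c1=O` share one core; compound 3 `COc1ccc([C@H](C)N(Cc2ccc(C(C)(C)C)cc2)Cc2cc3cc(C4CC4)ccc3[nH]c2=O)cc1` and the as yet unmeasured compound 4 `C[C@@H](c1ccc(OC(F)(F)F)cc1)N(Cc1ccc(C(C)(C)C)cc1)Cc1cc2cc(C3CC3)ccc2[nH]c1=O` share another, and the difference between the two cores is not broken down here. In a toxicity assay on MDCK cells (Canis lupus familiaris) for cytotoxicity, read by crystal violet staining, with a stated time of 48 h (on this read-out lower numbers stand for higher toxicity in this test and higher numbers for lower toxicity in this test), compound 1 gives only a limit, > 10000 nM. In this assay compound 2 gives only a limit as well, > 10000 nM. In this assay compound 3 likewise gives only a limit, > 10000 nM.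

The change from compound 1 to compound 2 is trifluoromethyl in place of methyl on an oxygen on an aromatic ring; the step it made, a step that the two limits leave unreadable from compound 1 to compound 2, is one the two limits leave unreadable. The change from compound 3 to compound 4 is trifluoromethyl in place of methyl on an oxygen on an aromatic ring, the same change carried onto the other core, and the place of the change reads the same in both cases. Everything the measured values show is summed up in the limit of > 10000 nM in this assay, at which 3 of the 3 values shown sit: no compound so far has reached a readable number, so no step in this read-out has yet been sized on either core.

Set beside a step that the two limits leave unreadable from compound 1 to compound 2, the step expected for compound 4 is a step that the limit leaves unreadable from compound 3 to compound 4, an expectation that rests on the limit of > 10000 nM in this assay, at which 3 of the 3 values shown sit, rather than on any measured movement. Compound 4 is accordingly estimated at 15000 nM, with the range from 8000 nM to 40000 nM, and most probably reported once more as a limit.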

Compound 4, half-maximal cytotoxic concentration: > 10000 nM
Compound 4 ended at the assay's limit (the forecaster's own chance of this, stated with the estimate: 85%); the middle value is on the limit's open side.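

In this assay compound 4 gives > 10000 nM as a limit and not a number. No new step can be read between compound 3 and compound 4, since every value stands at the same limit: the limit of > 10000 nM in this assay, at which 4 of the 4 values shown sit. The compounds shown leave open how large the change to trifluoromethyl in place of methyl is on either core, and whether it moves this read-out at all.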